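A few compounds are considered here, and "the series" means these few. Any claim that something is new, unique, unknown or untested is made for them only; others in the source may bear on it.

Working notes on the amide series, read in a functional assay on HepG2 cells (Homo sapiens) for antiproliferative activity, read by MTT assay, with a stated time of 24 h; on this read-out lower numbers stand for stronger inhibition and higher numbers for weaker inhibition. The measured compounds differ in the group on the amide carbonyl carbon: compound 1 (`COC(=O)c1scc(-c2ccc(NC(=O)c3ccc(F)c(Cl)n3)cc2)c1OC`) gives 10300 nM, compound 2 (`COC(=O)c1scc(-c2ccc(NC(=O)c3ccc(C(F)(F)F)cc3Br)cc2)c1OC`) gives 28200 nM, and compound 3 (`COC(=O)c1scc(-c2ccc(NC(=O)c3ccc(C#N)nc3)cc2)c1OC`) gives 22500 nM. Compound 3 lies within the scatter of compound 2 and carries a higher number than compound 1.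

The next entry is compound 4 (`COC(=O)c1scc(-c2ccc(NC(=O)c3ccc(C(F)(F)F)cc3)cc2)c1OC`), with 4-(trifluoromethyl)phenyl in place of 6-cyanopyridin-3-yl on a carbonyl carbon.

Among the measured compounds shown here, only one measured step bears directly on this place, a 2.2-fold higher number from compound 1 to compound 3 (0.34 log units; beyond the scatter), and it is modest and only just beyond the scatter. Compound 2, at 28200 nM, also holds a trifluoromethyl group, though it carries a bromine as well, and its value sits close to that of compound 3. For the measured compounds named here, no measured compound has exactly the entering group, so the data fix no direction for the change. All three values also stay within a narrow band, so a large move is not expected in this assay. The expected result is a 1.1-fold lower number from compound 3 to compound 4 (0.05 log units; within the scatter), which is estimated to stay within the scatter. The estimate for compound 4 is 20000 nM, with an expected range from 9000 nM to 45000 nM.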

Compound 4, half-maximal inhibitory concentration: 24600 nM
Estimate against measurement, compound 4: 1.2-fold (0.09 log units) below; the measured number falls inside the stated range.
By their numbers in this assay, from the lowest: compound 1; then compounds 3, 4 and 2 (each within the scatter of the next).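

Exchanging 6-cyanopyridin-3-yl for 4-(trifluoromethyl)phenyl on the carbonyl carbon gives a 1.1-fold higher number from compound 3 to compound 4 (0.04 log units; within the scatter) in this assay, so this position tolerates the loss of the nitrile and the ring nitrogen, and a group without hydrogen-bond acceptors, with no reading beyond the scatter. Among the compounds shown here, the first single-atom comparison at this ring gives a 1.1-fold lower number from compound 2 to compound 4 (0.06 log units; within the scatter) for hydrogen in place of bromo on an aromatic carbon, whereas a 2.4-fold higher number from compound 1 to compound 4 (0.38 log units; beyond the scatter) keeps the 6-chloro-5-fluoropyridin-2-yl amide of compound 1 modestly apart from compound 4 , as it stands apart from compound 3 . No measurement on hand accounts for any of these readings.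

Still open is whether the small separation of compound 1 comes from its chloro group, its fluoro group or the place of its ring nitrogen, as the compounds shown do not vary these one at a time. Also open, from the compounds shown here alone, is whether a basic or charged group on the carbonyl carbon, such as an aminomethylphenyl or a carboxylic acid on the phenyl ring, would leave the narrow band of values seen so far.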